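Moving the Nitro Group Around the Benzyl Ring

This account rests on a few compounds, and the source may have more. Where it says the series, first, only, none or still open, it means among the compounds named here.

Compound 1 `Brc1ccccc1CSc1nnc(-c2ccncc2)n1-c1ccccc1` carries a 2-bromophenyl group on the saturated chain carbon bound to a sulfur, compound 2 `Fc1ccc(CSc2nnc(-c3ccncc3)n2-c2ccccc2)cc1` a 4-fluorophenyl group at the same place, and compound 3 `O=[N+]([O-])c1ccccc1CSc1nnc(-c2ccncc2)n1-c1ccccc1` a 2-nitrophenyl group. In a functional assay on MCF7 cells (Homo sapiens) for inhibition, read by MTT assay, with a stated time of 48 h (a lower number here means a stronger inhibitor, a higher number a weaker inhibitor), compound 1 gives 16100 nM, and compound 2 gives 21100 nM. For compound 3 the assay reports only a limit, > 50000 nM, so compound 3 stands at the weak end of this small set without a number of its own. The step of a 1.3-fold higher number from compound 1 to compound 2 (0.12 log units; within the scatter) shows that swapping both the substituent and its ring position left the read-out unchanged within the scatter. The steps of an at least 3.1-fold higher number from compound 1 to compound 3 (0.49 log units; beyond the scatter) and an at least 2.3-fold higher number from compound 2 to compound 3 (0.37 log units; beyond the scatter) both run toward (the limit of > 50000 nM in this assay, at which 1 of the 3 values shown sits).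

Compound 4 `O=[N+]([O-])c1ccc(CSc2nnc(-c3ccncc3)n2-c2ccccc2)cc1` differs from compound 3 by 4-nitrophenyl in place of 2-nitrophenyl on a saturated chain carbon bound to a sulfur. For the measured compounds named here, no measured step moves a nitro group alone from one ring position to another, so the closest guide is the unchanged result when the ring position shifted between compound 1 and compound 2. Compound 4 is therefore expected to show no step beyond the scatter, a step that the limit leaves unreadable from compound 3 to compound 4, and to remain a weak inhibitor. The estimate for compound 4 in this assay is 60000 nM, expected between 20000 nM and 200000 nM, with a real chance that the assay again returns only a limit.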

Compound 4, half-maximal inhibitory concentration: 22800 nM
Beside the measured number, compound 4's estimate is 2.6-fold (0.42 log units) above it; the range from low to high includes it.
By their numbers in this assay, from the lowest: compounds 1, 2 and 4 (each within the scatter of the next). At a limit, above all of these: compound 3.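

In this assay, for the compounds shown here, moving the nitro group alone, with 4-nitrophenyl in place of 2-nitrophenyl on the saturated chain carbon bound to a sulfur, gave an at least 2.1-fold lower number from compound 3 to compound 4 (0.34 log units; beyond the scatter), so the read-out at this place depends on where the nitro group sits on the ring, which no earlier pair could show. The nitro group as such does not set compound 3 apart: the change from fluoro to nitro gave a 1.1-fold higher number from compound 2 to compound 4 (0.03 log units; within the scatter), and the change from 2-bromophenyl to 4-nitrophenyl gave a 1.4-fold higher number from compound 1 to compound 4 (0.15 log units; within the scatter). Among the compounds shown, only the 2-nitrophenyl group stands apart, and the true size of its step remains open, since compound 3 has only a limit: the limit of > 50000 nM in this assay, at which 1 of the 4 values shown sits.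

Going by these compounds, whether moving a bromo or fluoro group around the ring would matter in the same way stays open, as does what an amine or a carboxylic acid in place of the nitro group would give. On these data alone, it is also open whether the separation of compound 3 from compound 4 would hold in any setting other than this assay.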